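The compounds below may be only part of what the source reports. "The series", "measured", "known", "first", "only" and "open" are said of these compounds alone.

Measured compounds: compound 1 `CCC(C)C1NC(=O)N(C2CCCC2)C1=O`, compound 2 `CC(C)C1NC(=O)N(C2CCCC2)C1=O`, compound 3 `O=C1NC(c2ccccc2)C(=O)N1Cc1ccccc1`.

In a functional assay on SW-620 cells (Homo sapiens) for inhibition (on this read-out lower numbers stand for stronger inhibition and higher numbers for weaker inhibition), compound 1 gives only a limit, > 100000 nM. Compound 2 likewise gives only a limit, > 100000 nM. Compound 3 gives a number, 96800 nM. Compound 2 therefore stands at the limit of the assay and not at a measured value. Among the measured compounds shown here, the one step between measured compounds, a step that the two limits leave unreadable from compound 1 to compound 2, cannot be read because both of its ends sit at the limit of > 100000 nM in this assay, at which 2 of the 3 values shown sit. The change to compound 4 `O=C1NC(c2ccccc2)C(=O)N1C1CCCC1` is phenyl in place of isopropyl on a saturated ring carbon. For the measured compounds named here, no measured step bears directly on this change; compound 3 carries a phenyl on a saturated ring carbon of its core and gives a number just under the limit. On that basis compound 4 is expected to remain near the limit. The step from compound 2 to compound 4 is expected to be small, a number no higher from compound 2 to compound 4 (the limit leaves the size open). The estimate for compound 4 is 100000 nM, in the range 40000 nM to 300000 nM.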

Compound 4, half-maximal inhibitory concentration: > 100000 nM
Compound 4: no number, only a limit; the forecaster's own chance of this, stated with the estimate: 55%; the middle value sits exactly at the limit.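

Compound 4 gives only a limit, > 100000 nM, so the steps to it from compound 1 and compound 2 cannot be read: the limit of > 100000 nM in this assay, at which 3 of the 4 values shown sit.

The compounds shown leave open how large any effect of phenyl in place of isopropyl or sec-butyl is in this assay.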